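A few compounds are considered here, and "the series" means these few. Any claim that something is new, unique, unknown or untested is made for them only; others in the source may bear on it.

Compound 1 `CC(C)N1CCN(Cc2csc(N)c2C(=O)c2ccc(Cl)cc2)CC1` was tested in an assay on CHO cells for displacement of a labelled ligand from adenosine receptor A3 (Homo sapiens), read by scintillation counting, with a stated time of 120 min, tested at 10 uM (on this read-out higher numbers stand for more inhibition at the one concentration tested (going by the name of the read-out) and lower numbers for less inhibition), where compound 1 gives 0%. Two close relatives were measured alongside it. Compound 2 `Nc1scc(CN2CCN(c3cccc(Cl)c3Cl)CC2)c1C(=O)c1ccc(Cl)cc1` gives 0% in this assay, and compound 3 `COc1ccc(N2CCN(Cc3csc(N)c3C(=O)c3ccc(Cl)cc3)CC2)cc1` gives 0%. On these numbers compound 1 stands level with both: the step of no change at the digits printed from compound 1 to compound 2 (within the scatter), the step of no change at the digits printed from compound 1 to compound 3 (within the scatter) and the step of no change at the digits printed from compound 2 to compound 3 (within the scatter) are each within the scatter, so none of the three can be said to give a higher or lower number than another in this assay at the single concentration used.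

Compound 4 `Nc1scc(CN2CCN(c3ccccc3C(F)(F)F)CC2)c1C(=O)c1ccc(Cl)cc1` is the next member of the series and has not yet been measured in this assay. Relative to compound 1 the change is 2-(trifluoromethyl)phenyl in place of isopropyl on an amine nitrogen in a ring. The two measured steps that bear on it are those from compound 1, in which an aryl group also replaced the isopropyl on the amine nitrogen in the ring: the step of no change at the digits printed from compound 1 to compound 2 (within the scatter) and the step of no change at the digits printed from compound 1 to compound 3 (within the scatter), both flat. Neither the dichlorinated nor the methoxylated aryl group moved the read-out, so no shift beyond the scatter is expected for compound 4 either; the expected step is no change at the digits printed from compound 1 to compound 4 (within the scatter). Compound 4 is therefore estimated to give 0% in this assay, within a range from -8% to 12%.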

Compound 4, a percentage reported as inhibition, at one concentration (the size of the read-out at that concentration, not a potency): 0%
Compound 4: middle estimate and measured number agree at the digits printed; low and high end bracket the measured number.
By their numbers in this assay, from the lowest: compounds 1, 2, 3 and 4 (each within the scatter of the next).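

With the 2-(trifluoromethyl)phenyl group on the amine nitrogen in the ring, the read-out in this assay stays flat: the result is no change at the digits printed from compound 1 to compound 4 (within the scatter) and likewise no change at the digits printed from compound 3 to compound 4 (within the scatter) and also no change at the digits printed from compound 2 to compound 4 (within the scatter) in this series. The earlier compounds shown here showed this only for the 2,3-dichlorophenyl and 4-methoxyphenyl groups, so the flat result at this position now also covers an aryl group carrying fluorine, which enters with 10 heavy atoms where isopropyl leaves with 3. No measured result explains why the read-out stays the same across these groups.

Since all four compounds sit level at the one concentration tested, they cannot be ordered, and they do not show whether any group on this nitrogen can lift the read-out in this assay at all. From the compounds shown here alone, it remains open whether a benzyl group, an acetyl group or a simple hydrogen on that nitrogen, or a carboxylic acid elsewhere on the shared core, would give a different number.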